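A few compounds are considered here, and "the series" means these few. Any claim that something is new, unique, unknown or untested is made for them only; others in the source may bear on it.

Of the compounds shown here, three built on one shared core have been tested in a toxicity assay on KB cells (Homo sapiens) for cytotoxicity, read by fluorescence, with a stated time of 3 days; on this read-out higher numbers stand for an effect only at larger amounts of compound and lower numbers for an effect already at smaller amounts. Compound 1 `CCCCOC(=O)CNC(=O)[C@H](CSc1ccc([N+](=O)[O-])cc1[N+](=O)[O-])NC(=O)CC[C@H](NC(=O)CC(C)(C)C)C(=O)OCCCC` gives 250 uM in this assay. Compound 2 `CCCCOC(=O)CNC(=O)[C@H](CSc1ccc([N+](=O)[O-])cc1[N+](=O)[O-])NC(=O)CC[C@H](NC(C)=O)C(=O)OCCCC` reaches only a limit of this assay, > 300 uM. Compound 3 `CCCCOC(=O)CNC(=O)[C@H](CSc1ccc([N+](=O)[O-])cc1[N+](=O)[O-])NC(=O)CC[C@H](NC(=O)CCc1ccccc1)C(=O)OCCCC` likewise stands at a limit of this assay, > 300 uM. Two of the measured steps, an at least 1.2-fold higher number from compound 1 to compound 2 (0.07 log units; that floor lies within the scatter) and an at least 1.2-fold higher number from compound 1 to compound 3 (0.07 log units; that floor lies within the scatter), are bounded because of the limit of > 300 uM in this assay, at which 2 of the 3 values shown sit, and a step that the two limits leave unreadable from compound 2 to compound 3. Compound 4 `CCCCOC(=O)CNC(=O)[C@H](CSc1ccc([N+](=O)[O-])cc1[N+](=O)[O-])NC(=O)CC[C@H](Nc1nc(N)nc(Cl)n1)C(=O)OCCCC` differs from compound 3 by 4-amino-6-chloro-1,3,5-triazin-2-yl in place of phenethylcarbonyl on an amine nitrogen. None of the measured steps alters the amine nitrogen in this way, so they offer no direct guide, and the shown values hint at no effect beyond the scatter. The expected step is a number no higher from compound 3 to compound 4 (the limit leaves the size open). Compound 4 is thus estimated at 300 uM, with a range from 100 uM to 600 uM.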

Compound 4, concentration for half-maximal effect: > 300 uM
Compound 4 gave a limit, no number; the forecaster's own chance of this, stated with the estimate: 65%; the middle value lies on the limit itself.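

With 4-amino-6-chloro-1,3,5-triazin-2-yl on the amine nitrogen, this position now carries a group without a carbonyl, and compound 4 also gives only a limit in this assay, > 300 uM. Among these compounds, the one readable step is an at least 1.2-fold higher number from compound 1 to compound 4 (0.07 log units; that floor lies within the scatter). The steps from compound 2 and compound 3 to compound 4 cannot be read, because both ends of each are limits: the limit of > 300 uM in this assay, at which 3 of the 4 values shown sit.

Going by these compounds, what a free amine or a longer alkyl chain on this nitrogen would give in this assay stays open. Whether any group here can bring the number clearly below that of compound 1, 250 uM, is also unknown.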